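The compounds below may be only part of what the source reports. "The series", "measured", "known", "first", "only" and "open" are said of these compounds alone.

Values in an ADME assay on cells (Peritoneal macrophage cell, Mus musculus) for cytotoxicity, read by fluorescence and resazurin assay, with a stated time of 3 days (a lower number here means that less compound is tolerated, a higher number that more compound is tolerated), for the measured compounds:
Compound 1 (`O=C(Nc1cc(-c2ccccn2)n[nH]1)N1CCC(c2cccc(F)c2)CC1`) gives > 45000 nM as a limit
Compound 2 (`O=C(Nc1cc(-c2ccccn2)n[nH]1)N1CCC(c2ccc(Cl)cc2)CC1`) gives > 55000 nM as a limit

Neither entry is a number, since each is a limit of the assay. Compound 2 stands at > 55000 nM as a limit, so it has no exact place on the scale. The next compound is compound 3 (`O=C(Nc1cc(-c2ccccn2)n[nH]1)N1CCC(c2ccccc2)CC1`), which has hydrogen in place of chloro on an aromatic carbon, para to a large group, so that 4-chlorophenyl becomes phenyl (hydrogen in place of chloro on an aromatic carbon). Among the compounds with values here, one measured step bears on this change, and that is a step that the two limits leave unreadable from compound 1 to compound 2 with 4-chlorophenyl in place of 3-fluorophenyl on a saturated ring carbon. It offers no size to carry over, so no step beyond the scatter is expected in this assay and neither direction is favoured. The estimated change is an at least 1.1-fold lower number from compound 2 to compound 3 (0.04 log units; that floor lies within the scatter) and it is expected to stay within the scatter. For compound 3 the estimated value is 50000 nM with an expected range from 25000 nM to 100000 nM and the reading may well again be only a limit.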

Compound 3, half-maximal cytotoxic concentration: > 64000 nM
Compound 3: a limit, no number; the forecaster's own chance of this, stated with the estimate: 75%; at least 1.2-fold (0.10 log units) between middle value and limit.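

In this assay compound 3 gives > 64000 nM, which is a limit and not a number. Compound 1 and compound 2 also stand only as limits, so neither step to compound 3 can be read. The compounds shown leave open where any of the three lies on the scale of this assay, and whether swapping chloro, fluoro or hydrogen changes the reading at all.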